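The source may report more compounds than this note shows. Statements on the series, on what has been measured and on what is new or still open speak of the compounds shown alone.

Compound 1 `CN1CCN(c2cccc(Nc3nccc(-c4c[nH]c5ncccc45)n3)c2)CC1` and compound 2 `CC(=O)N1CCCN(c2cccc(Nc3nccc(-c4c[nH]c5ncccc45)n3)c2)CC1` share one core and differ only in the group on its outer aromatic carbon. In a functional assay on MV4-11 cells (Homo sapiens) for antiproliferative activity, read by resazurin assay, with a stated time of 72 h (on this read-out higher numbers stand for weaker inhibition of growth and lower numbers for stronger inhibition of growth), compound 1 gives 5 nM, and compound 2 gives 20 nM, the highest of the two numbers; the step is a 4.0-fold higher number from compound 1 to compound 2 (0.60 log units; beyond the scatter). Compound 3 `CC(=O)N1CCCN(c2cccc(Nc3nccc(-c4c[nH]c5cccnc45)n3)c2)CC1` keeps the 4-acetyl-1,4-diazepan-1-yl group of compound 2 and instead changes the bicyclic group on the aromatic carbon of the six-membered aromatic ring with 2 nitrogen: a group of 9 heavy atoms (7 carbon, 2 nitrogen; one five-membered aromatic ring with 1 hetero atom, one six-membered aromatic ring with 1 hetero atom) in place of a group of 9 heavy atoms (7 carbon, 2 nitrogen; one five-membered aromatic ring with 1 hetero atom, one six-membered aromatic ring with 1 hetero atom), on an aromatic carbon. Within the data shown here, no measured step bears on this change, since both measured compounds carry the same bicyclic group; the single measured step concerns a different position and gives no guide here. The expected step is therefore uncertain, and a modest loss is expected, a 7.5-fold higher number from compound 2 to compound 3 (0.88 log units; beyond the scatter). Compound 3 is expected to give about 150 nM in this assay, with a range from 20 nM to 1500 nM.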

Compound 3, concentration for 50% growth inhibition: 688 nM
Compound 3: the middle estimate sits 4.6-fold (0.66 log units) below what was measured, and the stated range covers the measured number.
By their numbers in this assay, from the lowest: compound 1; then compound 2; then compound 3.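

In this assay, the position on the six-membered aromatic ring with 2 nitrogen proves highly sensitive: with the 4-acetyl-1,4-diazepan-1-yl group held constant, rejoining the same atoms within the bicyclic group gives a 34-fold higher number from compound 2 to compound 3 (1.54 log units; beyond the scatter), a larger step than a 4.0-fold higher number from compound 1 to compound 2 (0.60 log units; beyond the scatter). The two bicyclic groups have the same atom counts, the same ring types and the same numbers of hydrogen-bond donors and acceptors, so none of these counts distinguishes them, and the large step goes with how the atoms are joined. Nothing available here accounts for the size of this step.

The compounds shown leave open whether the same rearrangement would cost as much alongside the 4-methylpiperazin-1-yl group of compound 1. They also leave open how a fluorine atom or an amine on the bicyclic group would fare at this position.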